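The compounds below may be only part of what the source reports. "The series", "measured", "known", "first", "only" and "open" are said of these compounds alone.

On these data alone, in an ADME assay on BJ cells (Homo sapiens) for cytotoxicity, with a stated time of 72 h (on this read-out lower numbers stand for an effect already at smaller amounts and higher numbers for an effect only at larger amounts of compound), compound 3 (`O=C(Nc1cccc(-c2nc3ccccc3s2)c1)c1cc([N+](=O)[O-])ccc1Cl`) gives only a limit, > 27000 nM, so its true position is unknown. Compound 4 (`Cc1ccc(-c2nc3ccccc3s2)cc1NC(=O)c1cc([N+](=O)[O-])ccc1Cl`) differs from it by methyl in place of hydrogen on an aromatic carbon. Among the compounds with values here, no measured step isolates this change. Compound 1 (`COC(=O)C1CCN(c2cc(Cl)c(C(=O)Nc3cc(-c4nc5ccccc5s4)ccc3C)cc2[N+](=O)[O-])CC1`) carries the same methyl and gives a limit, > 25000 nM. Compound 2 (`Cc1ccc(-c2nc3ccccc3s2)cc1NC(=O)c1cc([N+](=O)[O-])c(N2CCCCC2)cc1Cl`) also carries it and gives a limit, > 25000 nM. Within the data shown here, the one measured step, a step that the two limits leave unreadable from compound 1 to compound 2, lies elsewhere in the structure and has no readable size. With both methyl-bearing compounds at a limit, no shift beyond the scatter is expected in this assay, and no direction can be assigned. The expected change is a number no higher from compound 3 to compound 4 (the limit leaves the size open). Compound 4 is estimated at 27000 nM, within an expected range of 15000 nM to 45000 nM.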

Compound 4, half-maximal effective concentration: > 14000 nM
Compound 4: only a limit was reported; the forecaster's own chance of this, stated with the estimate: 85%; the middle value does not contradict the limit.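

Within the data shown here, compound 1, compound 2, compound 3 and compound 4 all give only limits in this assay, so no step among them can be read. On these data alone, the concentration at which any of them reaches the half-maximal effect remains open.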